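Acyl ring swap and an aniline substituent exchange

This account rests on a few compounds, and the source may have more. Where it says the series, first, only, none or still open, it means among the compounds named here.

Compound 1 `COc1cc(F)c(NC(=O)c2ccncc2)cc1Nc1nccc(-c2cn(C)c3ccccc23)n1` is the reference point of this small set. Among the compounds with values here, in a functional assay on NCI-H1975 cells (Homo sapiens) for antiproliferative activity, read by MTT assay, with a stated time of 72 h (on this read-out lower numbers stand for stronger inhibition and higher numbers for weaker inhibition), compound 1 gives 4370 nM, the lowest of the two numbers measured so far. Compound 2 `COc1cc(F)c(NC(=O)c2ncccn2)cc1Nc1nccc(-c2cn(C)c3ccccc23)n1` differs from it only in the ring attached to the carbonyl carbon; in this assay compound 2 gives 13500 nM, and the step of a 3.1-fold higher number from compound 1 to compound 2 (0.49 log units; beyond the scatter) is modest but beyond the scatter.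

Compound 3 `COc1cc(N(C)C)c(NC(=O)c2ccncc2)cc1Nc1nccc(-c2cn(C)c3ccccc23)n1` is not yet measured. It differs from compound 1 by dimethylamino in place of fluoro on an aromatic carbon. Within the data shown here, none of the measured steps touches this position: the single step at hand, a 3.1-fold higher number from compound 1 to compound 2 (0.49 log units; beyond the scatter), concerns the ring on the carbonyl carbon and not the substituent on the central aromatic ring, so it gives no direct guide to the size or direction of the coming change. Compound 1 itself sets the starting point at 4370 nM. With nothing bearing on this exchange, the expected step of a 1.1-fold lower number from compound 1 to compound 3 (0.04 log units; within the scatter) is one of no change beyond the scatter, in either direction. For compound 3 the estimate in this assay is therefore 4000 nM, with a range from 1500 nM to 12000 nM.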

Compound 3, half-maximal inhibitory concentration: 1470 nM
The estimate for compound 3 lay 2.7-fold (0.43 log units) above the measured number; measured number below the stated range.
By their numbers in this assay, from the lowest: compound 3; then compound 1; then compound 2.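

The position ortho to the ((pyridin-4-yl)carbonyl)amino group and para to a large group is not silent: in this assay, exchanging fluoro for dimethylamino gives a 3.0-fold lower number from compound 1 to compound 3 (0.47 log units; beyond the scatter), a modest step but one beyond the scatter. The number therefore responds to the substituent on this six-membered aromatic ring as well as to the ring on the carbonyl carbon, and the two changes run in opposite directions, since the acyl ring swap gave a 3.1-fold higher number from compound 1 to compound 2 (0.49 log units; beyond the scatter). Nothing available bears on what lies behind the lower number with dimethylamino in this place.

From the compounds shown here alone, with only fluoro and dimethylamino compared at this position, it remains open whether the lower number is particular to dimethylamino or would also appear with another amine, such as a piperazine or morpholine, or with a longer chain ending in a dimethylamino group. Going by these compounds, it is equally open whether the step from pyridin-4-yl to pyrimidin-2-yl on the carbonyl carbon keeps its direction and size when dimethylamino, rather than fluoro, occupies this position.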